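Ortho-Fluorophenyl Urea Expected Near Its Methoxy Analogues

The source may hold more compounds than are shown below. What is called first, only, known or untested is meant among the compounds shown, and "the series" means these compounds.

Compound 3 `COc1ccc(NC(=O)Nc2cccc(CNc3ncnc4ccccc34)c2)cc1` holds the lowest of the two numbers recorded in a functional assay on MGC-803 cells (Homo sapiens) for antiproliferative activity, read by MTT assay (a higher number here means a weaker inhibitor, a lower number a stronger inhibitor), where compound 3 gives 27300 nM. Compound 2 `COc1ccccc1NC(=O)Nc1cccc(CNc2ncnc3ccccc23)c1` stands nearest, giving 39300 nM in this assay, and the step is a 1.4-fold lower number from compound 2 to compound 3 (0.16 log units; within the scatter). Compound 1 `Cc1ccccc1NC(=O)Nc1cccc(CNc2ncnc3ccccc23)c1` reaches only a limit in this assay, namely > 50000 nM. Compound 4 `O=C(Nc1cccc(CNc2ncnc3ccccc23)c1)Nc1ccccc1F` differs from compound 3 by 2-fluorophenyl in place of 4-methoxyphenyl on an amide-type nitrogen. Among the compounds with values here, the steps that bear on this change are an at least 1.8-fold lower number from compound 1 to compound 3 (0.26 log units; that floor lies within the scatter) and an at least 1.2-fold lower number from compound 1 to compound 2 (0.10 log units; that floor lies within the scatter), together with the step between compound 2 and compound 3 noted above; all are floors or shifts within the scatter, one of them resting on (the limit of > 50000 nM in this assay, at which 1 of the 3 values shown sits). No step beyond the scatter is therefore expected in this assay, and the estimated step is a 1.3-fold higher number from compound 3 to compound 4 (0.11 log units; within the scatter). Compound 4 is estimated at 35000 nM, expected to fall between 14000 nM and 90000 nM.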

Compound 4, half-maximal inhibitory concentration: 33400 nM
The estimate for compound 4 lay 1.0-fold (0.02 log units) above the measured number, within the range that was stated.
By their numbers in this assay, from the lowest: compounds 3, 4 and 2 (each within the scatter of the next). At a limit, above all of these: compound 1.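

In this assay, 2-fluorophenyl on the amide-type nitrogen keeps the number within the scatter of both methoxy compounds, with a 1.2-fold higher number from compound 3 to compound 4 (0.09 log units; within the scatter) and a 1.2-fold lower number from compound 2 to compound 4 (0.07 log units; within the scatter) as the two steps, so this place tolerates losing the hydrogen-bond acceptor of the methoxy group without a step beyond the scatter. Against the methyl compound, an at least 1.4-fold lower number from compound 1 to compound 4 (0.17 log units; that floor lies within the scatter) is only a floor. Compound 1 stands at a limit of the assay: the limit of > 50000 nM in this assay, at which 1 of the 4 values shown sits.

Still open, going by these compounds, is whether a chloro, amino or carboxylic acid group on this phenyl ring would give a step beyond the scatter.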